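The source may report more compounds than this note shows. Statements on the series, on what has been measured and on what is new or still open speak of the compounds shown alone.

Measured so far in an ADME assay on MDBK cells (Bos taurus) for cytotoxicity, read by MTT assay, with a stated time of 72 h; on this read-out lower numbers stand for higher toxicity in this test and higher numbers for lower toxicity in this test:
compound 1 `FC(F)(F)c1ccc(NCc2cn(-c3ccccc3)nc2-c2ccc(C(F)(F)F)cc2)cc1` gives 26000 nM.
compound 2 `Clc1ccc(NCc2cn(-c3ccccc3)nc2-c2ccccc2)cc1` gives > 100000 nM, a limit of the assay.
compound 3 `Cc1ccc(NCc2cn(-c3ccccc3)nc2-c2ccc(C(F)(F)F)cc2)cc1` gives > 100000 nM, a limit of the assay.

Compound 3 thus stands at the limit of this assay, where one further value also sits (the limit of > 100000 nM in this assay, at which 2 of the 3 values shown sit). Going by the values given here, the only measured step, an at least 3.8-fold higher number from compound 1 to compound 3 (0.58 log units; beyond the scatter), sets trifluoromethyl against methyl and does not touch the change now in hand, (chloro in place of methyl on an aromatic carbon), which gives compound 4 `FC(F)(F)c1ccc(-c2nn(-c3ccccc3)cc2CNc2ccc(Cl)cc2)cc1`. Among the compounds with values here, no measured step bears on chloro in place of methyl; compound 2, which carries the same chloro, also sits at the limit. Compound 4 is therefore expected to remain at the limit, with a number no higher from compound 3 to compound 4 (the limit leaves the size open) as no step beyond the scatter. The estimate for compound 4 is 100000 nM, range 40000 nM to 300000 nM.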

Compound 4, half-maximal cytotoxic concentration: 44000 nM
The estimate for compound 4 lay 2.3-fold (0.36 log units) above the measured number; low and high end bracket the measured number.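

Chloro in place of methyl at this position, para to a large group, does not stay at the limit in this assay, with an at least 2.2-fold lower number from compound 3 to compound 4 (0.35 log units; beyond the scatter), and trifluoromethyl in place of hydrogen on an aromatic carbon gives an at least 2.2-fold lower number from compound 2 to compound 4 (0.35 log units; beyond the scatter). Chloro and trifluoromethyl at this position are not separated, with a 1.7-fold higher number from compound 1 to compound 4 (0.23 log units; within the scatter). The first two steps give only minimum sizes, as each starts from a limit: the limit of > 100000 nM in this assay, at which 2 of the 4 values shown sit.

From the compounds shown here alone, whether an amine, a carboxylic acid or a methoxy group at this position would stay at the limit remains open.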